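This account rests on a few compounds, and the source may have more. Where it says the series, first, only, none or still open, it means among the compounds named here.

Values in a functional assay on HeLa cells (Homo sapiens) for inhibition, read by sulforhodamine B assay, with a stated time of 74 h (a higher number here means a weaker inhibitor, a lower number a stronger inhibitor), follow.

- compound 1 `Cc1ccc(S(=O)(=O)N2C(=O)COC23C=CC(=O)C=C3)cc1` gives 180 nM
- compound 2 `O=C1C=CC2(C=C1)OCC(=O)N2S(=O)(=O)c1ccc(Cl)cc1`, a limit of the assay, gives > 10000 nM
- compound 3 `COc1ccc(S(=O)(=O)N2C(=O)COC23C=CC(=O)C=C3)cc1` gives 880 nM

Of the two values that are not limits, the higher belongs to compound 3, and the gap is (a 4.9-fold higher number from compound 1 to compound 3 (0.69 log units; beyond the scatter)). Compound 4 `O=C1C=CC2(C=C1)OCC(=O)N2S(=O)(=O)c1ccc(N2CCCC2=O)cc1` carries 2-oxopyrrolidin-1-yl in place of methoxy on an aromatic carbon.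

All three measured changes fall on this same aromatic carbon. Both departures from methyl raised the number, (a 4.9-fold higher number from compound 1 to compound 3 (0.69 log units; beyond the scatter)) and (an at least 55-fold higher number from compound 1 to compound 2 (1.74 log units; beyond the scatter)), while the remaining step runs the other way (an at least 11-fold lower number from compound 2 to compound 3 (1.05 log units; beyond the scatter)). The place is clearly sensitive, so a modest to large step to a higher number is expected in this assay. For compound 4 the estimated value is 2500 nM, with an expected range of 400 nM to 10000 nM. This estimate means an expected step of (a 2.8-fold higher number from compound 3 to compound 4 (0.45 log units; beyond the scatter)).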

Compound 4, half-maximal inhibitory concentration: 880 nM
Compound 4: the middle estimate sits 2.8-fold (0.45 log units) above what was measured; the range from low to high includes it.
By their numbers in this assay, from the lowest: compound 1; then compounds 3 and 4 (each within the scatter of the next). At a limit, above all of these: compound 2.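

On this aromatic carbon, 2-oxopyrrolidin-1-yl, a five-membered non-aromatic ring of 6 heavy atoms, cannot be told apart from the 2 heavy atoms of methoxy in this assay: no change at the digits printed from compound 3 to compound 4 (within the scatter). Methyl therefore stays ahead of this much larger group too, with a 4.9-fold higher number from compound 1 to compound 4 (0.69 log units; beyond the scatter). Compound 2, with chloro, stands at a limit of the assay, so its step is only a bound, an at least 11-fold lower number from compound 2 to compound 4 (1.05 log units; beyond the scatter): the limit of > 10000 nM in this assay, at which 1 of the 4 values shown sits.

Going by these compounds, whether an ethyl group or an amine on this carbon would match methyl remains open. So does whether fluoro would behave like chloro.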